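The compounds below may be only part of what the source reports. "The series", "measured", "known", "first", "only" and "open" are said of these compounds alone.

Measured so far:
Compound 1 `Cc1ccc(OCC(=O)N(Cc2cccs2)c2cccnc2)cc1`: 198 nM
Compound 2 `CCN(Cc1cccs1)C(=O)COc1ccc(C(F)(F)F)cc1`: 236 nM

In an assay on HEK293 cells for agonist activity at transient receptor potential cation channel subfamily M member 8 (Homo sapiens), read by fluorescence and calcium flux, with a stated time of 15 min (on this read-out lower numbers stand for an effect already at smaller amounts and higher numbers for an effect only at larger amounts of compound), compound 1 gives 198 nM and compound 2 gives 236 nM; the two numbers lie within the usual scatter of each other, so neither compound can be placed ahead of the other. Compound 3 `C=CCN(Cc1cccs1)C(=O)COc1ccc(C)cc1` has not yet been measured. It differs from compound 1 in one place: allyl in place of pyridin-3-yl on an amide-type nitrogen. Among the measured compounds shown here, no measured pair shows this change, so its size is unknown. A step no larger than the scatter is expected, in either direction, because compound 2 gives 236 nM with a chain on that nitrogen. The expected step is a 1.3-fold higher number from compound 1 to compound 3 (0.12 log units; within the scatter). Compound 3 is expected to give 260 nM, between 100 nM and 700 nM.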

Compound 3, half-maximal effective concentration: 20 nM
Estimate against measurement, compound 3: 13-fold (1.11 log units) above; the measured number lies below the stated range.
By their numbers in this assay, from the lowest: compound 3; then compounds 1 and 2 (each within the scatter of the next).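

In this assay, allyl in place of pyridin-3-yl on the amide-type nitrogen gives a 9.9-fold lower number from compound 1 to compound 3 (1.00 log units; beyond the scatter), so what sits at this position clearly matters. The aromatic ring is not needed here for an effect at low amounts, and an open chain with a double bond serves better in this pair. Nothing at hand explains this step.

As far as these compounds go, whether the double bond itself matters stays open, and a propyl group on that nitrogen would test it. How a longer chain or a chain ending in an amine would behave is also unknown.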